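A Larger Selenium Group Replacing Methylsulfanyl

The source may hold more compounds than are shown below. What is called first, only, known or untested is meant among the compounds shown, and "the series" means these compounds.

Compound 1 `CS/C(=N\C(=O)c1cc2ccccc2s1)NC(=O)c1cc2ccccc2s1` is the starting point of this comparison. In a functional assay on HT-29 cells (Homo sapiens) for cytotoxicity, read by MTT assay, with a stated time of 72 h (on this read-out lower numbers stand for stronger inhibition of growth and higher numbers for weaker inhibition of growth), compound 1 gives 88200 nM. A second pair with a different core shows how one change behaves. Compound 2 `CS/C(=N\C(=O)c1ccco1)NC(=O)c1ccco1` carries the methylsulfanyl group, and in this assay compound 2 reaches only a limit, > 100000 nM, not a number. Compound 3 `O=C(/N=C(/NC(=O)c1ccco1)[Se]Cc1ccccc1)c1ccco1` carries the larger group in its place, and in this assay compound 3 gives 89100 nM. The change from compound 2 to compound 3 is a group of 8 heavy atoms (7 carbon, 1 selenium; one six-membered aromatic ring of carbon only) in place of a group of 2 heavy atoms (1 carbon, 1 sulfur; no ring), on a carbon with a double bond to nitrogen and it produced an at least 1.1-fold lower number from compound 2 to compound 3 (0.05 log units; that floor lies within the scatter); the floor of that step rests on a limit, because of the limit of > 100000 nM in this assay, at which 1 of the 3 values shown sits. The numbers for compound 1 and compound 3 sit close together. The difference between the core of compound 1 and the core of compound 2 is not broken down here.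

Compound 4 `O=C(/N=C(/NC(=O)c1cc2ccccc2s1)[Se]Cc1ccccc1)c1cc2ccccc2s1` has not yet been measured in this assay. It differs from compound 1 by a group of 8 heavy atoms (7 carbon, 1 selenium; one six-membered aromatic ring of carbon only) in place of a group of 2 heavy atoms (1 carbon, 1 sulfur; no ring), on a carbon with a double bond to nitrogen, the same change that was made from compound 2 to compound 3. The step expected from compound 1 to compound 4 in this assay is a 1.2-fold lower number from compound 1 to compound 4 (0.07 log units; within the scatter), and this expectation rests on the step of an at least 1.1-fold lower number from compound 2 to compound 3 (0.05 log units; that floor lies within the scatter), which is small and bounded only by a limit. The estimated value for compound 4 in this assay is 75000 nM, with a plausible range expected from 30000 nM to 150000 nM.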

Compound 4, concentration for total growth inhibition: > 100000 nM
Compound 4 ended at the assay's limit; the forecaster's own chance of this, stated with the estimate: 30%; at least 1.3-fold (0.12 log units) between middle value and limit.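

In this assay compound 4 gives > 100000 nM, which is a limit of the assay and not a number. On the core of compound 1, putting the larger selenium group in place of methylsulfanyl gives an at least 1.1-fold higher number from compound 1 to compound 4 (0.05 log units; that floor lies within the scatter), and this is a floor on the step and not its measured size. Set side by side, the two steps do not show that the change carries over from one core to the other, nor do they show that the two cores respond to it differently: the same change on two cores in this assay, an at least 1.1-fold lower number (0.05 log units; that floor lies within the scatter) from compound 2 to compound 3 and an at least 1.1-fold higher number (0.05 log units; that floor lies within the scatter) from compound 1 to compound 4; the limit leaves it open whether they differ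

The compounds shown leave open which part of the change matters, since the entering group differs from methylsulfanyl both in holding selenium in place of sulfur and in carrying a six-membered aromatic ring; a methylselanyl group, or a sulfur group with the same ring, would separate the two. They also leave open whether a different group on the carbon with a double bond to nitrogen, such as an amine or a longer carbon chain, would give a value clear of the limit on either core.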